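This account rests on a few compounds, and the source may have more. Where it says the series, first, only, none or still open, it means among the compounds named here.

In a functional assay on HCT-116 cells (Homo sapiens) for antiproliferative activity, read by MTT assay, with a stated time of 48 h (on this read-out higher numbers stand for weaker inhibition and lower numbers for stronger inhibition), compound 1 `Cc1nnc(Sc2cc(NC(=O)c3ccc(Cl)cc3)c3ccccc3c2O)s1` gives > 100000 nM, a limit of the assay rather than a number. Compound 2 `COc1ccc(/C=C/C(=O)Nc2cc(Sc3ncn[nH]3)c(O)c3ccccc23)cc1OC` likewise returns only a limit in this assay, > 100000 nM. For the measured compounds named here, both measured values sit at the limit of > 100000 nM in this assay, at which 2 of the 2 values shown sit, so compound 1 has no place on a scale of numbers, and no step between measured compounds is available. Compound 3 `O=C(Nc1cc(Sc2nncs2)c(O)c2ccccc12)c1ccc(Cl)cc1` differs from compound 1 by hydrogen in place of methyl on an aromatic carbon. Going by the values given here, with no measured step to lean on, no shift beyond the scatter is expected, and the estimated step is a step that the limit leaves unreadable from compound 1 to compound 3. Compound 3 is therefore expected near 150000 nM, within 50000 nM to 500000 nM, most probably again reported as a limit.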

Compound 3, half-maximal inhibitory concentration: > 100000 nM
Compound 3: a limit, no number (the forecaster's own chance of this, stated with the estimate: 80%); the middle value does not contradict the limit.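

No step can be read from compound 1 to compound 3 in this assay, as both values are limits: the limit of > 100000 nM in this assay, at which 3 of the 3 values shown sit. The compounds shown leave open how 5-methyl-1,3,4-thiadiazol-2-yl and 1,3,4-thiadiazol-2-yl compare, and which structures give a numerical value in this assay.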